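Isopropyl for phenyl on the chain carbon: tolerability notes

This account rests on a few compounds, and the source may have more. Where it says the series, first, only, none or still open, it means among the compounds named here.

Compound 1 `CCCC(CCOc1ccc(-c2ccc(Cl)cc2)cc1)CCN1CCN(c2ccncc2)C1=O` gives > 25000 nM in an ADME assay on cells (Homo sapiens) for cytotoxicity; a lower number here means that less compound is tolerated, a higher number that more compound is tolerated; this is a limit of the assay, not a number.
Compound 2 `O=C1N(CCC(CCOc2ccc(-c3ccc(Cl)cc3)cc2)C(F)(F)F)CCN1c1ccncc1` gives > 12500 nM; again a limit.
Compound 3 `O=C1N(CCC(CCOc2ccc(-c3ccc(Cl)cc3)cc2)c2ccccc2)CCN1c1ccncc1` gives > 25000 nM; again a limit.

Compound 3 thus stands at the limit of > 25000 nM in this assay, at which 2 of the 3 values shown sit. Compound 2 alone stands at the limit of > 12500 nM in this assay, at which 1 of the 3 values shown sits. Compound 4 `CC(C)C(CCOc1ccc(-c2ccc(Cl)cc2)cc1)CCN1CCN(c2ccncc2)C1=O` carries isopropyl in place of phenyl on a saturated chain carbon bound to two saturated chain carbons. Going by the values given here, the steps that bear on this position are a step that the two limits leave unreadable from compound 1 to compound 3 and a step that the two limits leave unreadable from compound 2 to compound 3, with a step that the two limits leave unreadable from compound 1 to compound 2 alongside; none of them yields a readable size. With every measured value a limit, no direction can be drawn, and compound 4 is expected to remain at the limit as well, an estimated step that the limit leaves unreadable from compound 3 to compound 4. For compound 4 the estimate is 40000 nM, between 15000 nM and 150000 nM.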

Compound 4, half-maximal cytotoxic concentration: > 25000 nM
Compound 4 was reported as a limit; the forecaster's own chance of this, stated with the estimate: 85%; the middle value lies beyond the limit too.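

Compound 4, like compound 1, compound 2 and compound 3, is reported only as a limit, and none of its steps to these compounds can be read. The compounds shown leave open whether any group on this chain carbon changes tolerability.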